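A Smaller Amide Substituent and Its Expected Cytotoxicity

The compounds below may be only part of what the source reports. "The series", "measured", "known", "first", "only" and "open" are said of these compounds alone.

In an ADME assay on HEp-2 cells (Homo sapiens) for cytotoxicity, read by CCK-8 assay, with a stated time of 6 days (on this read-out lower numbers stand for higher toxicity in this test and higher numbers for lower toxicity in this test), compound 1 `NCCNc1cc(N2CCN(S(=O)(=O)c3ccccc3)CC2)nc2ccccc12` gives 20500 nM. Compound 2 `NCCNc1cc(N2CCN(C(=O)C3(c4ccccc4)CCCC3)CC2)nc2ccccc12` is reported in this assay only as a limit, > 100000 nM. The result for compound 2 thus sits at the limit of > 100000 nM in this assay, at which 1 of the 2 values shown sits, so it is a boundary and not a number, and no fixed gap between compound 1 and compound 2 can be stated beyond what the two values show.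

Compound 3 `CCC(=O)N1CCN(c2cc(NCCN)c3ccccc3n2)CC1` differs from compound 2 by ethyl in place of 1-phenylcyclopentyl on a carbonyl carbon. For the measured compounds named here, no measured pair isolates this change, so its size cannot be read from the data. The step is expected to be modest, an at least 1.4-fold lower number from compound 2 to compound 3 (0.15 log units; that floor lies within the scatter), towards somewhat higher toxicity at most, and possibly none beyond the scatter. Compound 3 is therefore estimated at 70000 nM, between 20000 nM and 150000 nM, with a real chance that this assay again reports only a limit.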

Compound 3, half-maximal cytotoxic concentration: > 100000 nM
Compound 3: no number, only a limit; the forecaster's own chance of this, stated with the estimate: 45%; middle value at least 1.4-fold (0.15 log units) from the limit.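

In this assay compound 3, like compound 2, is reported only as a limit: the limit of > 100000 nM in this assay, at which 2 of the 3 values shown sit. The step between these two compounds therefore cannot be read, and ethyl in place of 1-phenylcyclopentyl on a carbonyl carbon shows no measurable change in this read-out. The comparison with compound 1 can be read, however: propanoyl in place of phenylsulfonyl on an amine nitrogen in a ring gives an at least 4.8-fold higher number from compound 1 to compound 3 (0.68 log units; beyond the scatter), so compound 1 alone of the three carries a number here.

On these data alone, how far compound 2 and compound 3 lie beyond their limit stays open, and so does whether the two groups differ at all. As far as these compounds go, it is also open whether methylsulfonyl or benzoyl on the same nitrogen would give a number like that of compound 1 or reach the limit.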